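Chloro-to-Fluoro Swap Read on Ovarian Cancer Cell Growth

A few compounds are considered here, and "the series" means these few. Any claim that something is new, unique, unknown or untested is made for them only; others in the source may bear on it.

Compound 1 `O=C(c1cc2ccccc2o1)N1N=C(c2ccccc2)CC1c1ccc(F)cc1`: 9.94 ug/mL
Compound 2 `O=C(c1cc2ccccc2o1)N1N=C(c2ccccc2)CC1c1ccc(Cl)cc1`: 5.13 ug/mL
Compound 3 `O=C(c1cc2ccccc2o1)N1N=C(c2ccc(Cl)cc2)CC1c1ccccc1`: 13.6 ug/mL

All three compounds were tested in a functional assay on A2780 cells (Homo sapiens) for antiproliferative activity, read by MTT assay, with a stated time of 72 h; on this read-out lower numbers stand for stronger inhibition and higher numbers for weaker inhibition. Compound 2 and compound 1 share one core and differ only by fluoro in place of chloro on an aromatic carbon, a change that gave a 1.9-fold higher number from compound 2 to compound 1 (0.29 log units; within the scatter). Compound 3 carries the same atoms as compound 2 joined differently; the difference between the two cores is not broken down here. Compound 4 `O=C(c1cc2ccccc2o1)N1N=C(c2ccc(F)cc2)CC1c1ccccc1` has not yet been measured. It differs from compound 3 by fluoro in place of chloro on an aromatic carbon, the same change as that from compound 2 to compound 1. Because a 1.9-fold higher number from compound 2 to compound 1 (0.29 log units; within the scatter) stayed within the scatter, a step of similar size is expected, namely a 1.5-fold higher number from compound 3 to compound 4 (0.17 log units; within the scatter). Compound 4 is therefore estimated at 20 ug/mL, with a range from 8 ug/mL to 45 ug/mL.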

Compound 4, half-maximal inhibitory concentration: 11.8 ug/mL
Estimate against measurement, compound 4: 1.7-fold (0.23 log units) above; measured number inside the range.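

In this assay, fluoro in place of chloro gave a 1.2-fold lower number from compound 3 to compound 4 (0.06 log units; within the scatter), so on this second core the change again produced no step beyond the scatter. Set beside the earlier step, the new one does not differ from it: the same change on two cores in this assay, a 1.9-fold higher number (0.29 log units; within the scatter) from compound 2 to compound 1 and a 1.2-fold lower number (0.06 log units; within the scatter) from compound 3 to compound 4, 2.2-fold (0.35 log units) apart, within the scatter of two such steps. This shows that the swap from 4-chlorophenyl to 4-fluorophenyl carried across these two cores with little effect on the number, but it does not establish a direction for the change or show that it would behave the same way on any other core.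

Going by these compounds, whether an amine, a methoxy group or a nitrile in the same place would move the number beyond the scatter remains open. So does whether either core would respond differently to a carboxylic acid there.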